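A few compounds are considered here, and "the series" means these few. Any claim that something is new, unique, unknown or untested is made for them only; others in the source may bear on it.

Measured so far:
compound 1 `COc1nn(C)c2nc(C)nc(NS(=O)(=O)c3cccc(Cl)c3Cl)c12` — 631 nM
compound 2 `COc1nc(NS(=O)(=O)c2cccc(Cl)c2Cl)c2c(OC)nn(C)c2n1` — 794 nM
compound 3 `CCNc1nc(NS(=O)(=O)c2cccc(Cl)c2Cl)c2c(OC)nn(C)c2n1` — 251 nM

In a functional assay on cells for antagonist activity at C-C chemokine receptor type 4 (Homo sapiens), read by GTPgammaS binding (on this read-out lower numbers stand for stronger inhibition and higher numbers for weaker inhibition), compound 3 stands at the lowest number of the three. Both steps leading to it lie beyond the scatter, a 2.5-fold lower number from compound 1 to compound 3 (0.40 log units; beyond the scatter) and a 3.2-fold lower number from compound 2 to compound 3 (0.50 log units; beyond the scatter), whereas a 1.3-fold higher number from compound 1 to compound 2 (0.10 log units; within the scatter) lies within it. Compound 4 `COc1nn(C)c2nc(NC3COC3)nc(NS(=O)(=O)c3cccc(Cl)c3Cl)c12` differs from compound 3 by oxetan-3-yl in place of ethyl on a nitrogen on an aromatic ring. For the measured compounds named here, no measured step swaps one group for another on that nitrogen; the steps that bear on it are only the two that bring the ethylamino group in, each modest in size. The amino linkage itself is kept, so the step is expected to be small. For compound 4 the expected step is a 1.6-fold higher number from compound 3 to compound 4 (0.20 log units; within the scatter), giving an estimate of 400 nM with a range from 150 nM to 1000 nM.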

Compound 4, half-maximal inhibitory concentration in the C-C chemokine receptor type 4 assay: 10000 nM
Estimate against measurement, compound 4: 25-fold (1.40 log units) below, and the stated range ends below it.
By their numbers in the C-C chemokine receptor type 4 assay, from the lowest: compound 3; then compounds 1 and 2 (each within the scatter of the next); then compound 4.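

In the C-C chemokine receptor type 4 assay, this nitrogen proves far more sensitive than the earlier modest steps suggested: oxetan-3-yl in place of ethyl gives a 40-fold higher number from compound 3 to compound 4 (1.60 log units; beyond the scatter), and the (oxetan-3-yl)amino group also loses to the methoxy and methyl groups, with a 13-fold higher number from compound 2 to compound 4 (1.10 log units; beyond the scatter) and a 16-fold higher number from compound 1 to compound 4 (1.20 log units; beyond the scatter). In a physicochemical assay for lipophilicity (on this read-out lower numbers stand for lower lipophilicity and higher numbers for higher lipophilicity), compound 3 gives 4.2 and compound 4 gives 2.2 and the same change comes with a large drop in lipophilicity: the measured distribution coefficient of compound 3, 4.2, and of compound 4, 2.2, a number 2.00 log units lower (beyond the scatter)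

On these data alone, whether the loss of activity follows that drop or the ring itself stays open. A cyclobutyl group on the same nitrogen, with a four-membered ring but no oxygen, would help tell these apart.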